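The source may report more compounds than this note shows. Statements on the series, on what has been measured and on what is new or still open speak of the compounds shown alone.

Of the compounds shown here, two have so far been measured in a functional assay on NCI-H460 cells (Homo sapiens) for inhibition, read by MTT assay, with a stated time of 24 h, tested at 100 ug/mL; a higher number here means more inhibition of growth at the concentration tested, a lower number less inhibition of growth. Compound 1 (`O=C(CCCCC1CCSS1)Nc1ccc(Cl)cn1`) gives 58.6%, and compound 2 (`O=C(CCCCC(S)CCS)Nc1ccccn1`) gives 11.7%, the lower of the two numbers and a gap beyond the scatter. Compound 3 (`O=C(CCCCC(S)CCS)Nc1ccc(Cl)cn1`) departs from compound 2 in one place: chloro in place of hydrogen on an aromatic carbon, which is chloro in place of hydrogen on an aromatic carbon, two atoms from the ring nitrogen. Within the data shown here, no measured pair shows this change on its own, so its size remains uncertain. Among the measured compounds shown here, the only guide is compound 1 at 58.6%, which also carries the chloro, and it suggests that growth inhibition may rise. The expected change is a number 18.3 percentage points higher from compound 2 to compound 3 (beyond the scatter), upward and beyond the scatter. For compound 3 the estimated value is 30%, with an expected range from 12% to 55%.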

Compound 3, percent growth inhibition at one concentration: 55.8%
The estimate for compound 3 lay 25.8 percentage points below the measured number; the whole stated range lies below it.
By their numbers in this assay, from the lowest: compound 2; then compounds 3 and 1 (each within the scatter of the next).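

In this assay, chloro in place of hydrogen on an aromatic carbon, two atoms from the ring nitrogen, now has a step of its own, and it is large: a number 44.1 percentage points higher from compound 2 to compound 3 (beyond the scatter). With the chloro kept, the open chain of 5 heavy atoms in place of the group holding the five-membered non-aromatic ring changes little, a number 2.8 percentage points lower from compound 1 to compound 3 (within the scatter), so in this pair the ring makes no difference that can be told from scatter. No measured evidence on hand accounts for either step.

As far as these compounds go, it remains open whether the chloro would give a step of similar size on the compound carrying the five-membered ring in its chain. Also open, from the compounds shown here alone, is whether a bromo, methyl or methoxy group at this same place would match the chloro.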